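Adding a Second Fluoro to the Aryl Ring

The source may report more compounds than this note shows. Statements on the series, on what has been measured and on what is new or still open speak of the compounds shown alone.

Of the compounds shown here, three built on one shared core have been measured in a functional assay on CHO cells with adenosine receptor A1 (Homo sapiens) as the target, read by cAMP accumulation and immunoassay, with a stated time of 6 min, tested at 0.01 uM; a higher number here means a weaker effect of the compound at the concentration tested, a lower number a stronger effect. Compound 1, `Nc1scc(CN2CCN(c3ccc(Cl)cc3F)CC2)c1C(=O)c1ccc(Cl)cc1`, gives -9.2%. Compound 2, `Nc1scc(CN2CCN(c3ccccc3C(F)(F)F)CC2)c1C(=O)c1ccc(Cl)cc1`, gives 0%. Compound 3, `Nc1scc(CN2CCN(c3ccccc3F)CC2)c1C(=O)c1ccc(Cl)cc1`, gives 2.1%, the highest of the three numbers, though its gap to compound 2 lies within the scatter; only its gap to compound 1 is larger than that, a number 11.3 percentage points higher from compound 1 to compound 3 (beyond the scatter).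

Compound 4, `Nc1scc(CN2CCN(c3cccc(F)c3F)CC2)c1C(=O)c1ccc(Cl)cc1`, is compound 3 with one alteration: fluoro in place of hydrogen on an aromatic carbon.

Within the data shown here, two measured steps bear on this. The closest analogy is the step of a number 11.3 percentage points higher from compound 1 to compound 3 (beyond the scatter), where removing a halogen from the same ring raised the number modestly; putting a halogen back in might therefore lower it. The step of a number 2.1 percentage points higher from compound 2 to compound 3 (within the scatter), swapping one group on that ring for another, stayed within the scatter. Taken together, a small downward move or none beyond the scatter is expected for compound 4, estimated as a number 4.1 percentage points lower from compound 3 to compound 4 (within the scatter).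

The estimate for compound 4 in this assay is -2%, expected to fall between -14% and 10%.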

Compound 4, a percentage reported as activity, at one concentration (the size of the read-out at that concentration, not a potency): -13%
For compound 4 the middle estimate is 11 percentage points above the measured one, within the range that was stated.
By their numbers in this assay, from the lowest: compounds 4, 1, 2 and 3 (each within the scatter of the next, the first and the last beyond it).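

In this assay, a fluoro placed on this aromatic carbon, ortho to the existing fluoro group, lowers the number beyond the scatter (a number 15.1 percentage points lower from compound 3 to compound 4 (beyond the scatter)), so this position responds to a single added atom even on a ring that already carries a fluoro. The 2,3-difluorophenyl group also gives a lower number than 2-(trifluoromethyl)phenyl (a number 13 percentage points lower from compound 2 to compound 4 (beyond the scatter)), but it cannot be told apart from 4-chloro-2-fluorophenyl (a number 3.8 percentage points lower from compound 1 to compound 4 (within the scatter)), so two different placements of a second halogen give readings within the scatter of each other. No measurement shown here accounts for these shifts.

Going by these compounds, whether a methoxy, an amine or a carboxylic acid on this same carbon would move the number as fluoro does remains open. Also open, on these data alone, is how a reading at one concentration relates to potency.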